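The source may hold more compounds than are shown below. What is called first, only, known or untested is meant among the compounds shown, and "the series" means these compounds.

Measured so far in an ADME assay on blood (Homo sapiens) for pharmacokinetics; a lower number here means that the compound disappears faster, a higher number that the compound lasts longer:
- compound 1 `COC(=O)CCNC(=O)[C@@H]1O[P@](=O)(OCOC(=O)c2ccnn2C)OCC1(C)C` gives < 0.16 h, a limit of the assay rather than a number.
- compound 2 `COC(=O)CCNC(=O)[C@@H]1O[P@](=O)(Oc2ccc(C(F)(F)F)cc2)OCC1(C)C` gives > 1 h, also a limit.
- compound 3 `COC(=O)CCNC(=O)[C@@H]1O[P@@](=O)(OCOC(=O)c2ccnn2C)OCC1(C)C` gives > 1 h, again a limit.

Compound 1 thus stands at the short end of the range in this assay (the limit of < 0.16 h in this assay, at which 1 of the 3 values shown sits), while the other two stand at the long end (the limit of > 1 h in this assay, at which 2 of the 3 values shown sit). Compound 1 and compound 3 differ only in configuration (the fact that compounds 1 and 3 differ only in the configuration as drawn), and that single change gives an at least 6.2-fold higher number from compound 1 to compound 3 (0.79 log units; beyond the scatter).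

Compound 4 `COC(=O)CCNC(=O)[C@@H]1O[P@](=O)(OCOC(=O)c2scnc2C(C)(C)C)OCC1(C)C` keeps the configuration of compound 1 and changes (4-(tert-butyl)-1,3-thiazol-5-yl in place of 1-methyl-1H-pyrazol-5-yl on a carbonyl carbon). Among the compounds with values here, no measured step involves this kind of change; the only step starting from compound 1 is the configurational one. For compound 4 a half-life near that of compound 1 is therefore expected, an at least 1.2-fold higher number from compound 1 to compound 4 (0.09 log units; that floor lies within the scatter), with an estimate of 0.2 h, ranging from 0.08 h to 0.6 h.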

Compound 4, half-life: 0.44 h
The estimate for compound 4 lay 2.2-fold (0.34 log units) below the measured number; measured number inside the range.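

The group on the carbonyl carbon also matters, not only the configuration at phosphorus: in this assay, 4-(tert-butyl)-1,3-thiazol-5-yl in place of 1-methyl-1H-pyrazol-5-yl gives an at least 2.7-fold higher number from compound 1 to compound 4 (0.43 log units; beyond the scatter). This step starts from a limit of the assay, so only its minimum size is known. Nothing measured here explains why this change lengthens the half-life. On these data alone, it stays open whether the tert-butyl group or the thiazole ring carries the change, and how a phenyl ring or an open alkyl chain on this carbonyl carbon would behave. As far as these compounds go, the opposite phosphorus configuration with the 4-(tert-butyl)-1,3-thiazol-5-yl group also remains open.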